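The source may report more compounds than this note shows. Statements on the series, on what has been measured and on what is new or still open speak of the compounds shown alone.

Series values in a functional assay on CCRF-CEM cells (Homo sapiens) for inhibition, read by MTT assay, with a stated time of 72 h; a lower number here means a stronger inhibitor, a higher number a weaker inhibitor
- compound 1 `COc1cc(NC(C)CCCNC(=O)Nc2cccc(Cl)c2)c2ncccc2c1` gives 22000 nM
- compound 2 `COc1cc(NC(C)CCCNC(=O)NNC(=O)Nc2ccc(Cl)cc2)c2ncccc2c1` gives 108000 nM
- compound 3 `COc1cc(NC(C)CCCNC(=O)Nc2ccc(Cl)cc2)c2ncccc2c1` gives 24000 nM

Compound 3 lies within the scatter of its 3-chlorophenyl counterpart (a 1.1-fold higher number from compound 1 to compound 3 (0.04 log units; within the scatter)) and well away from the longer compound 2 (a 4.5-fold lower number from compound 2 to compound 3 (0.65 log units; beyond the scatter)). Next is compound 4 `COc1cc(NC(C)CCCNC(=O)NNC(=O)Nc2cccc(Cl)c2)c2ncccc2c1`, with ((3-chlorophenyl)carbamoyl)amino in place of 4-chlorophenyl on an amide-type nitrogen. Going by the values given here, two measured steps bear on this exchange (a 4.5-fold lower number from compound 2 to compound 3 (0.65 log units; beyond the scatter) and a 4.9-fold higher number from compound 1 to compound 2 (0.69 log units; beyond the scatter)) and they are of similar, modest size. Swapping 3-chlorophenyl for 4-chlorophenyl alone gave no step beyond the scatter (a 1.1-fold higher number from compound 1 to compound 3 (0.04 log units; within the scatter)). In this assay a higher number of comparable size is therefore expected for compound 4 (a 4.2-fold higher number from compound 3 to compound 4 (0.62 log units; beyond the scatter)). Compound 4 is estimated at 100000 nM (expected range 50000 nM to 200000 nM) .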

Compound 4, half-maximal inhibitory concentration: 81000 nM
For compound 4 the middle estimate is 1.2-fold (0.09 log units) above the measured one; low and high end bracket the measured number.
By their numbers in this assay, from the lowest: compounds 1 and 3 (each within the scatter of the next); then compounds 4 and 2 (each within the scatter of the next).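

The exchange of 4-chlorophenyl for 3-chlorophenyl now has a second reading on the longer ((chlorophenyl)carbamoyl)amino compounds, and it again stays within the scatter (a 1.3-fold lower number from compound 2 to compound 4 (0.12 log units; within the scatter)): the same change on two cores in this assay, a 1.1-fold higher number (0.04 log units; within the scatter) from compound 1 to compound 3 and a 1.3-fold higher number (0.12 log units; within the scatter) from compound 4 to compound 2, 1.2-fold (0.09 log units) apart, within the scatter of two such steps. Lengthening the group on the amide-type nitrogen to ((3-chlorophenyl)carbamoyl)amino gives a modest rise beyond the scatter, both with the chlorine placement kept (a 3.7-fold higher number from compound 1 to compound 4 (0.57 log units; beyond the scatter)) and with it changed (a 3.4-fold higher number from compound 3 to compound 4 (0.53 log units; beyond the scatter)). The length of this group, not the chlorine placement, therefore tracks the number in these four compounds.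

Open, from the compounds shown here alone, is whether an unsubstituted phenyl or a 4-methoxyphenyl on this nitrogen would depart from compounds 1 and 3. Going by these compounds, a carboxylic acid or an amine on the ring is equally open.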